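Aromatic Ring Swap on a Shared Amine Core

The source may hold more compounds than are shown below. What is called first, only, known or untested is meant among the compounds shown, and "the series" means these compounds.

Measured so far in an ADME assay on MDCK cells (Canis lupus familiaris) for cytotoxicity, read by microscopy, with a stated time of 48 h; on this read-out lower numbers stand for higher toxicity in this test and higher numbers for lower toxicity in this test:
- compound 1 `CCc1csc(CN[C@@H]2C[C@H]3C[C@@H]([C@H]2C)C3(C)C)c1`: 25000 nM
- compound 2 `C[C@H]1[C@H](NCc2cccs2)C[C@H]2C[C@@H]1C2(C)C`: 25000 nM
- compound 3 `CCCCc1csc(CN[C@@H]2C[C@H]3C[C@@H]([C@H]2C)C3(C)C)c1`: 12500 nM

Compound 2 stands level with compound 1 at the digits shown, and together they give the highest numbers of the three; the only other measured compound, compound 3, lies a 2.0-fold lower number from compound 2 to compound 3 (0.30 log units; within the scatter). Going by the values given here, all three measured steps are small: no change at the digits printed from compound 1 to compound 2 (within the scatter), a 2.0-fold lower number from compound 1 to compound 3 (0.30 log units; within the scatter) and a 2.0-fold lower number from compound 2 to compound 3 (0.30 log units; within the scatter) each stay within the scatter, so nothing among the measured compounds has moved this read-out in a meaningful way.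

Compound 4 `Cc1n[nH]cc1CN[C@@H]1C[C@H]2C[C@@H]([C@H]1C)C2(C)C` differs from compound 2 in one place: 3-methyl-1H-pyrazol-4-yl in place of thiophen-2-yl on a saturated chain carbon bound to an amine nitrogen. Among the compounds with values here, none of the measured steps exchanges one aromatic ring for another; they only add or remove small alkyl groups on the thiophene ring or its chain, and each of those changes left the read-out essentially unchanged. Within the data shown here, there is therefore no measured step that directly speaks to this exchange, and no basis in these data for expecting a move in either direction beyond the scatter. The expected step is no change at the digits printed from compound 2 to compound 4 (within the scatter), an estimate only. Compound 4 is thus expected to give about 25000 nM, with a range from 12500 nM to 50000 nM.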

Compound 4, minimum cytotoxic concentration: > 100000 nM
Compound 4 gave a limit, no number; the forecaster's own chance of this, stated with the estimate: 20%; middle value at least 4.0-fold (0.60 log units) from the limit.
By their numbers in this assay, from the lowest: compounds 3, 1 and 2 (each within the scatter of the next). At a limit, above all of these: compound 4.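

In this assay, going by these compounds alone, the earlier steps only added or removed alkyl groups around the thiophene ring and all stayed within the scatter, whereas exchanging the ring itself gives an at least 4.0-fold higher number from compound 2 to compound 4 (0.60 log units; beyond the scatter). This makes the aromatic ring on the saturated chain carbon bound to an amine nitrogen the first place in this small set where a change moves the read-out beyond the scatter, here in the direction of lower toxicity in this test. Compound 4 stands at a limit of the assay and not at a number, so the step has a known minimum but no known size, and this is the point to keep in mind when reading it: the limit of > 100000 nM in this assay, at which 1 of the 4 values shown sits.

The entering 3-methyl-1H-pyrazol-4-yl group differs from thiophen-2-yl at once in its ring hetero atoms, its methyl group and its hydrogen-bond donor, so compound 4 alone cannot show which of these differences goes with the step. Going by these compounds, it also stays open whether a pyrazole ring without the methyl group, or a phenyl or pyridine ring on the same chain carbon, would give a similar result.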